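Half-life series: substituents on the hydroxy-bearing chain carbon

The compounds below may be only part of what the source reports. "The series", "measured", "known", "first", "only" and "open" are said of these compounds alone.

Measured compounds in an ADME assay, in phosphate buffer, at 28 degrees C, at pH 7.0; on this read-out higher numbers stand for a longer-lived compound and lower numbers for a shorter-lived compound:
- compound 1, `CC(C)(C)C1=C(C(=O)O)N2C(=O)[C@H](CO)[C@H]2O1`, gives 5 h
- compound 2, `CC(C)(C)C1=C(C(=O)O)N2C(=O)[C@H]([C@H](O)c3ccncc3)[C@H]2O1`, gives 6.4 h
- compound 3, `CC(C)(C)C1=C(C(=O)O)N2C(=O)[C@H]([C@H](O)CCc3ccccc3)[C@H]2O1`, gives 21 h

Compound 1 holds the lowest number of the three in this assay. Its nearest neighbour is compound 2, with a 1.3-fold higher number from compound 1 to compound 2 (0.11 log units; within the scatter); its furthest is compound 3, with a 4.2-fold higher number from compound 1 to compound 3 (0.62 log units; beyond the scatter). Between the two substituted analogues the step is a 3.3-fold higher number from compound 2 to compound 3 (0.52 log units; beyond the scatter).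

Compound 4, `C[C@H](O)[C@H]1C(=O)N2C(C(=O)O)=C(C(C)(C)C)O[C@H]12`, has not yet been measured. It differs from compound 1 by methyl in place of hydrogen on a saturated chain carbon bound to an oxygen on a saturated carbon and a saturated ring carbon.

The two measured steps that bear on this are both additions at the same place on compound 1. The pyridin-4-yl entry stays within the scatter, a 1.3-fold higher number from compound 1 to compound 2 (0.11 log units; within the scatter), while the phenethyl entry gives a modest gain, a 4.2-fold higher number from compound 1 to compound 3 (0.62 log units; beyond the scatter). The methyl entering in compound 4 is the smallest of the three groups, and the data do not show that size alone drives the gain seen with compound 3. The expectation for compound 4 in this assay is therefore a step within the scatter, at most a slight rise, a 1.3-fold higher number from compound 1 to compound 4 (0.11 log units; within the scatter).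

Compound 4 is estimated at 6.5 h, with a range of 3.5 h to 13 h.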

Compound 4, half-life: 7.1 h
Compound 4: middle estimate off by 1.1-fold (0.04 log units), on the low side; low and high end bracket the measured number.
By their numbers in this assay, from the lowest: compounds 1, 2 and 4 (each within the scatter of the next); then compound 3.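

In this assay, methyl on this saturated chain carbon gives a 1.4-fold higher number from compound 1 to compound 4 (0.15 log units; within the scatter) and so, like the pyridin-4-yl entry with a 1.3-fold higher number from compound 1 to compound 2 (0.11 log units; within the scatter) at the same place, leaves the read-out within the scatter of the unsubstituted hydroxymethyl parent. The change from hydroxymethyl to 1-hydroxyethyl therefore shows that adding a carbon group here does not by itself carry the number beyond the scatter, and phenethyl, with a 4.2-fold higher number from compound 1 to compound 3 (0.62 log units; beyond the scatter) as its step, remains the only one of the three entries that does. No measurement at hand explains why methyl and phenethyl part in this way.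

Still open, going by these compounds, is which part of phenethyl goes with the longer half-life: a benzyl or a phenyl group at the same carbon would test the length of the link to the ring, while a longer saturated chain such as n-butyl would test whether the ring is needed at all. Also open is how an amine or a carboxylic acid on the end of such a chain would read, since the compounds shown carry only methyl, pyridin-4-yl and phenethyl at this place.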